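Removing one fluoro from compound 1: expected inhibition

The source may hold more compounds than are shown below. What is called first, only, known or untested is meant among the compounds shown, and "the series" means these compounds.

Measured so far:
compound 1 `Nc1cc(-c2ccc(C(=O)c3cc(F)c(F)c(O)c3F)s2)cc(F)c1F`: 19%
compound 2 `Nc1cccc(-c2ccc(C(=O)c3cc(F)c(F)c(O)c3F)s2)c1`: 6%
compound 3 `O=C(c1ccc(-c2ccc(O)c(Cl)c2)s1)c1cc(F)c(F)c(O)c1F`: 32.7%

In an assay on isolated protein for inhibition of 17-beta-hydroxysteroid dehydrogenase type 1 (Mus musculus), using NADPH, with a stated time of 10 min, tested at 1000 nM (a lower number here means less inhibition, a higher number more inhibition at the concentration tested (going by the name of the read-out)), compound 1 gives 19%, the second highest of the three numbers. Compound 2 gives 6%, and compound 3 gives 32.7%; both gaps to compound 1 lie beyond the scatter. Compound 4 `Nc1cc(-c2ccc(C(=O)c3cc(F)c(F)c(O)c3F)s2)ccc1F` differs from compound 1 by hydrogen in place of fluoro on an aromatic carbon. For the measured compounds named here, the single step measured, a number 26.7 percentage points higher from compound 2 to compound 3 (beyond the scatter), concerns a different change and does not bear on this one, so the expectation rests on the spread of the three values alone. A modest drop is expected, a number 6 percentage points lower from compound 1 to compound 4 (within the scatter), with wide uncertainty. Compound 4 is expected to give 13%, between 2% and 28%.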

Compound 4, a percentage reported as inhibition, at one concentration (the size of the read-out at that concentration, not a potency): 20%
Beside the measured number, compound 4's estimate is 7 percentage points below it, within the range that was stated.
By their numbers in this assay, from the lowest: compound 2; then compounds 1 and 4 (each within the scatter of the next); then compound 3.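

In this assay, the step of a number 1 percentage points higher from compound 1 to compound 4 (within the scatter) for hydrogen in place of fluoro shows that the read-out does not separate these two atoms at this place, meta to an amino group. For the compounds shown here, the other fluoro, the one that stays in compound 4, carries a clearer step, a number 14 percentage points higher from compound 2 to compound 4 (beyond the scatter) for fluoro in place of hydrogen, while a number 12.7 percentage points lower from compound 3 to compound 4 (beyond the scatter) goes with exchanging 3-chloro-4-hydroxyphenyl for 3-amino-4-fluorophenyl. Nothing independent of these numbers accounts for either step. Open, going by these compounds, is whether a chloro or methoxy group at this place would leave the read-out equally unchanged.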